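This account rests on a few compounds, and the source may have more. Where it says the series, first, only, none or still open, it means among the compounds named here.

In a functional assay on HEK293 cells (Homo sapiens) for cytotoxicity (a higher number here means that more compound is tolerated, a lower number that less compound is tolerated), compound 1 `COc1ccc([C@H]2CC(=O)N(c3cccc(C)c3)C2)cc1OC1CCCC1` gives > 10000 nM, which is a limit and not a number. Compound 2 `CCCCNc1cccc(N2C[C@@H](c3ccc(OC)c(OC4CCCC4)c3)CC2=O)c1` gives > 10000 nM, again only a limit. Compound 2 therefore stands at the limit of > 10000 nM in this assay, at which 2 of the 2 values shown sit, and no exact position can be given for it.

Compound 3 `COc1ccc(S(=O)(=O)Nc2cccc(N3C[C@@H](c4ccc(OC)c(OC5CCCC5)c4)CC3=O)c2)cc1` has (4-methoxyphenyl)sulfonyl in place of butyl on a nitrogen on an aromatic ring. Within the data shown here, the one measured step bearing on this change is a step that the two limits leave unreadable from compound 1 to compound 2, which introduced the butylamino group altered here. That step offers no size to carry over. The expectation rests only on the two limits, and no step beyond the scatter is expected in this assay, in either direction. The expected step is a step that the limit leaves unreadable from compound 2 to compound 3. Compound 3 is estimated at 15000 nM, with an expected range of 6000 nM to 40000 nM.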

Compound 3, half-maximal cytotoxic concentration: > 10000 nM
Compound 3: no number, only a limit; the forecaster's own chance of this, stated with the estimate: 80%; the middle value does not contradict the limit.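

In this assay no new step can be read among compound 1, compound 2 and compound 3, since each gives only a limit and not a number: the limit of > 10000 nM in this assay, at which 3 of the 3 values shown sit. The compounds shown leave open whether methyl, butylamino or ((4-methoxyphenyl)sulfonyl)amino on the shared core changes tolerance at all.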